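The source may report more compounds than this note shows. Statements on the series, on what has been measured and on what is new or still open speak of the compounds shown alone.

Compound 1 `Cc1ccc(CCOc2ccc(-c3c(C)nc(C)c([C@H](OC(C)(C)C)C(=O)O)c3N3CCC(C)(C)CC3)cc2)cc1` gives in a toxicity assay on MT2 cells (Homo sapiens) for cytotoxicity, read by XTT assay, with a stated time of 4 days (a lower number here means that less compound is tolerated, a higher number that more compound is tolerated), only the limit >= 33500 nM.
Compound 2 `Cc1nc(C)c([C@H](OC(C)(C)C)C(=O)O)c(N2CCC(C)(C)CC2)c1-c1ccc(OCCc2ccc(Cl)cc2)cc1` gives in this assay only the limit >= 33500 nM.
Compound 3 `Cc1nc(C)c([C@H](OC(C)(C)C)C(=O)O)c(N2CCC(C)(C)CC2)c1-c1ccc(OCCc2ccc(F)c(F)c2)cc1` gives in this assay only the limit >= 33500 nM.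

Among the measured compounds shown here, compound 3 thus stands where all three measured compounds stand, at the limit of >= 33500 nM in this assay, at which 3 of the 3 values shown sit, and no compound shows a number. Compound 4 `Cc1nc(C)c([C@H](OC(C)(C)C)C(=O)O)c(N2CCC(C)(C)CC2)c1-c1ccc(OCCc2ccccn2)cc1` differs from compound 3 by pyridin-2-yl in place of 3,4-difluorophenyl on a saturated chain carbon, two bonds along the chain from an oxygen on an aromatic ring. The steps that could bear on this change, a step that the two limits leave unreadable from compound 1 to compound 3 and a step that the two limits leave unreadable from compound 2 to compound 3, give no readable size, so no direction can be taken from them, and no step beyond the scatter is expected. Compound 4 is therefore expected to reach the same limit, with an estimate of 33500 nM and a range from 15000 nM to 70000 nM. The expected step is a number no higher from compound 3 to compound 4 (the limit leaves the size open).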

Compound 4, half-maximal cytotoxic concentration: >= 25000 nM
Compound 4 gave a limit, no number; the forecaster's own chance of this, stated with the estimate: 80%; the middle value is on the limit's open side.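

Among the compounds shown here, compound 1, compound 2, compound 3 and compound 4 all give only limits in this assay, so no step among them can be read. The compounds shown leave open how much of each compound the cells actually tolerate, and whether pyridin-2-yl in place of 3,4-difluorophenyl changes that.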